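This account rests on a few compounds, and the source may have more. Where it says the series, first, only, none or still open, it means among the compounds named here.

Series notes. In a physicochemical assay for lipophilicity (a higher number here means a more lipophilic compound, a lower number a more polar compound), compound 1 `Clc1ccccc1C1=NC(c2ccccc2)CO1` gives 3.56. Among the measured compounds shown here, the only other measured compound, compound 2 `CSc1ccccc1C1=NC(c2ccccc2)CO1`, gives 3.5, so the two stand level within the scatter. Compound 3 `Clc1ccc(C2=NC(c3ccccc3)CO2)c(Cl)c1` is still unmeasured. It differs from compound 1 by chloro in place of hydrogen on an aromatic carbon, meta to a chloro group and para to a large group (chloro in place of hydrogen on an aromatic carbon).

For the measured compounds named here, the one measured step is a number 0.06 log units lower from compound 1 to compound 2 (within the scatter), with methylsulfanyl in place of chloro on an aromatic carbon. That step swaps one group for another, whereas here a group enters where hydrogen stood, so it gives no direct guide to size. Going by the values given here, no measured step covers this change, and the expectation rests on the change itself and on the starting 3.56 of compound 1. An upward move in this assay beyond the scatter is expected, estimated as a number 0.64 log units higher from compound 1 to compound 3 (beyond the scatter). For compound 3 the estimated value is 4.2, with an expected range of 3.8 to 4.6.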

Compound 3, partition coefficient: 4.4
Beside the measured number, compound 3's estimate is 0.20 log units below it, and the stated range covers the measured number.
By their numbers in this assay, from the lowest: compounds 2 and 1 (each within the scatter of the next); then compound 3.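

In this assay the series now has a step in which a group enters where hydrogen stood: chloro in place of hydrogen on an aromatic carbon, meta to a chloro group and para to a large group, gives a number 0.84 log units higher from compound 1 to compound 3 (beyond the scatter) and so shows that this place on the ring can shift the number beyond the scatter. The earlier swap, a number 0.06 log units lower from compound 1 to compound 2 (within the scatter), did not separate its two compounds and said nothing about this place. No measured evidence bearing on the size of this step is available.

The compounds shown leave open whether an amine or a methoxy group at this same place would move the number in the same direction and by a similar size. They also leave open whether the same chloro entry on compound 2 would give a similar step.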